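The source may hold more compounds than are shown below. What is called first, only, known or untested is meant among the compounds shown, and "the series" means these compounds.

Compound 1 `c1coc(-c2ccccc2OCC2=NCCN2)c1` gives 1.26 nM in a functional assay for activation of Alpha-1A adrenergic receptor (Homo sapiens), read by calcium flux; on this read-out lower numbers stand for an effect already at smaller amounts and higher numbers for an effect only at larger amounts of compound. Compound 2 `Cc1ccoc1-c1ccccc1OCC1=NCCN1` gives 3.16 nM in this assay.

Of the two measured compounds, compound 2 stands at the higher number: the step of a 2.5-fold higher number from compound 1 to compound 2 (0.40 log units; beyond the scatter) is modest but beyond the scatter. Compound 3 `Cc1cc(-c2ccccc2OCC2=NCCN2)sn1` carries 3-methyl-1,2-thiazol-5-yl in place of 3-methylfuran-2-yl on an aromatic carbon. Among the compounds with values here, no measured step involves an exchange of the five-membered ring itself; the only known step, a 2.5-fold higher number from compound 1 to compound 2 (0.40 log units; beyond the scatter), concerns a methyl on that ring and does not settle how the ring swap will read out. The step from compound 2 to compound 3 in this assay is therefore expected to be small, a 1.6-fold higher number from compound 2 to compound 3 (0.20 log units; within the scatter), with no clear direction. Compound 3 is estimated at 5 nM, within 1.5 nM to 20 nM.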

Compound 3, half-maximal effective concentration: 158 nM
The estimate for compound 3 lay 32-fold (1.50 log units) below the measured number, outside the stated range (above it).
By their numbers in this assay, from the lowest: compound 1; then compound 2; then compound 3.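

Exchanging the five-membered ring itself on this aromatic carbon matters far more in this assay than adding a methyl to it: 3-methyl-1,2-thiazol-5-yl in place of 3-methylfuran-2-yl gives a 50-fold higher number from compound 2 to compound 3 (1.70 log units; beyond the scatter). Measured against the unmethylated furan-2-yl, the gap is a 130-fold higher number from compound 1 to compound 3 (2.10 log units; beyond the scatter). Nothing available accounts for this large step.

Open, from the compounds shown here alone, is whether the large step belongs to the 1,2-thiazole ring as such or to its combination with the methyl. An amine or a carboxylic acid in place of that methyl could help to separate the two.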